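Cyclobutyl side-chain variants of the shared core

This account rests on a few compounds, and the source may have more. Where it says the series, first, only, none or still open, it means among the compounds named here.

Measured compounds in an assay on isolated protein for agonist activity at prostaglandin E2 receptor EP3 subtype (Homo sapiens); a lower number here means that less compound is needed, a higher number that more compound is needed for the effect:
compound 1, `CCCCC1([C@H](O)/C=C/[C@H]2COC(=O)N2CCSc2nc(C(=O)O)cs2)CCC1`, 3.9 nM
compound 2, `CC(C)(CCCCF)[C@H](O)/C=C/[C@H]1COC(=O)N1CCSc1nc(C(=O)O)cs1`, 4.7 nM
compound 3, `O=C(O)c1csc(SCCN2C(=O)OC[C@@H]2/C=C/[C@@H](O)C2(CCCCF)CCC2)n1`, 10 nM

Compound 3 has the highest number of the three: it is above compound 2 by a 2.1-fold higher number from compound 2 to compound 3 (0.33 log units; beyond the scatter) and above compound 1 by a 2.6-fold higher number from compound 1 to compound 3 (0.41 log units; beyond the scatter). Compound 4, `CC#CCC1([C@H](O)/C=C/[C@H]2COC(=O)N2CCSc2nc(C(=O)O)cs2)CCC1`, is not yet measured. Its difference from compound 3 is prop-1-yn-1-yl in place of 3-fluoropropyl on a saturated chain carbon bound to a saturated ring carbon.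

Within the data shown here, two measured steps bear on this change. The step from compound 1 to compound 3 added a fluoro on the saturated chain and gave a 2.6-fold higher number from compound 1 to compound 3 (0.41 log units; beyond the scatter); compound 4 undoes that fluoro and so is expected to move back toward the value of compound 1. The step from compound 1 to compound 2 shows that rearranging the saturated chain leaves the number about where it was, a 1.2-fold higher number from compound 1 to compound 2 (0.08 log units; within the scatter). Among the measured compounds shown here, a triple bond in this chain has no precedent among the measured compounds, so the direction of that part of the change is open. On balance a modest fall is expected, a 2.0-fold lower number from compound 3 to compound 4 (0.30 log units; within the scatter), and compound 4 is estimated at 5 nM, within 2 nM to 14 nM.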

Compound 4, half-maximal effective concentration: 18 nM
Beside the measured number, compound 4's estimate is 3.6-fold (0.56 log units) below it; measured number outside the range, above it.
By their numbers in this assay, from the lowest: compounds 1 and 2 (each within the scatter of the next); then compounds 3 and 4 (each within the scatter of the next).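

In this assay, prop-1-yn-1-yl in place of propyl on a saturated chain carbon bound to a saturated ring carbon gives a 4.6-fold higher number from compound 1 to compound 4 (0.66 log units; beyond the scatter), so at this position the triple bond is not a neutral replacement for the saturated chain of compound 1. Against the other saturated chain, 1-(but-2-yn-1-yl)cyclobutyl in place of 5-fluoro-1,1-dimethylpentyl gives a 3.8-fold higher number from compound 2 to compound 4 (0.58 log units; beyond the scatter), while prop-1-yn-1-yl in place of 3-fluoropropyl gives a 1.8-fold higher number from compound 3 to compound 4 (0.26 log units; within the scatter), which leaves the alkyne chain and the fluorinated chain of compound 3 unseparated. No evidence on the reason for these steps is at hand.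

A but-2-en-1-yl chain, with a double bond at the same place, would show whether the loss follows the triple bond alone. Also open, on these data alone, is whether a longer chain carrying the triple bond, or a terminal nitrile, stays close to compound 1.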